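A Larger, Charged Group on the Shared Core

The source may report more compounds than this note shows. Statements on the series, on what has been measured and on what is new or still open speak of the compounds shown alone.

In a functional assay with Oryctolagus cuniculus as the target (a higher number here means a weaker inhibitor, a lower number a stronger inhibitor), compound 1 `COc1ccc(-c2nc(/N=C(\N)NC(C)C)sc2-c2ccc(OC)cc2)cc1` reads > 100 nM, which is a limit of the assay and not a number. For the measured compounds named here, compound 2 `C/N=C(/NC)Nc1nc(-c2ccc(OC)cc2)c(-c2ccc(OC)cc2)s1` gives 970 nM, the only true number so far, so it is the sole anchor for any forecast. The next structure is compound 3 `COc1ccc(-c2nc(/N=C(\N)[N+]3(C)CCCCC3)sc2-c2ccc(OC)cc2)cc1`, and the change is a group of 10 heavy atoms (7 carbon, 3 nitrogen; one six-membered non-aromatic ring with 1 hetero atom) in place of a group of 6 heavy atoms (3 carbon, 3 nitrogen; no ring), on an aromatic carbon. The entering group brings a six-membered non-aromatic ring and a net charge of +1, while the group that leaves has no ring and no net charge.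

Going by the values given here, the only measured step, a step that the limit leaves unreadable from compound 1 to compound 2, has no readable size, and the limit of > 100 nM in this assay, at which 1 of the 2 values shown sits, is the only other evidence. Among the compounds with values here, no measured step therefore sets the size of this one. The change is large, so a modest weakening in this assay is expected, though only as a cautious judgement. The step expected here is a 2.1-fold higher number from compound 2 to compound 3 (0.31 log units; beyond the scatter). For compound 3 the estimated value is 2000 nM, with an expected range from 300 nM to 12000 nM.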

Compound 3, half-maximal inhibitory concentration: > 1000 nM
Compound 3 was reported as a limit; the forecaster's own chance of this, stated with the estimate: 25%; the middle value lies beyond the limit too.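

Putting the group with one six-membered non-aromatic ring with 1 hetero atom and a net charge of +1 on this aromatic carbon, next to the ring nitrogen and next to the ring sulfur, gives an at least 1.0-fold higher number from compound 2 to compound 3 (0.01 log units; that floor lies within the scatter) in this assay. Compound 3 reads > 1000 nM, which is a limit and not a number, so this larger, charged group gives no sign here of a stronger inhibitor than the smaller, uncharged group of compound 2, though the true size of the weakening, if there is one, stays hidden. For the compounds shown here, the steps from compound 1 to compound 2 and from compound 1 to compound 3 cannot be read, so only one step has even a floor, and that floor rests on a limit: the limit of > 1000 nM in this assay, at which 1 of the 3 values shown sits.

From the compounds shown here alone, how far compound 3 lies past its limit remains open, and the ring and the net charge enter together, so their separate shares in the result cannot be told apart. A morpholine ring or a simple dimethylamino group at this place would be needed to show whether an uncharged group of similar size reads differently in this assay.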